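Swapping the pyridine arm on the shared core

This account rests on a few compounds, and the source may have more. Where it says the series, first, only, none or still open, it means among the compounds named here.

Compound 1 `Nc1nc(C2CCCO2)nc2sc(Cc3ccccc3)cc12` gives 2950 nM in a functional assay on CHO-K1 cells for antagonist activity at adenosine receptor A1 (Homo sapiens), read by a beta-galactosidase reporter and cAMP accumulation, with stated times of 15 min and 6 h; a higher number here means a weaker inhibitor, a lower number a stronger inhibitor.
Compound 2 `Nc1nc(-c2ccncc2)nc2sc(Cc3ccccc3)cc12` gives 812 nM in this assay.
Compound 3 `Nc1nc(-c2cccc(Cl)n2)nc2sc(Cc3ccccc3)cc12` gives > 1000 nM in this assay, which is a limit of the assay and not a number.

Compound 3 thus stands at the limit (the limit of > 1000 nM in this assay, at which 1 of the 3 values shown sits), so its exact place among the three is not readable. Compound 4 `N#Cc1cncc(-c2nc(N)c3cc(Cc4ccccc4)sc3n2)c1` differs from compound 3 in one place: 5-cyanopyridin-3-yl in place of 6-chloropyridin-2-yl on an aromatic carbon. For the measured compounds named here, two measured steps bear on this change, both involving a pyridine ring on the same carbon of the core. The step of an at least 1.2-fold higher number from compound 2 to compound 3 (0.09 log units; that floor lies within the scatter) shows that moving from one pyridine to another gave a floor within the scatter. The step of a 3.6-fold lower number from compound 1 to compound 2 (0.56 log units; beyond the scatter) shows a modest gain when a pyridine replaced the oxolane ring. Going by the values given here, no measured step touches a nitrile, so the expectation leans on compound 2 and its 812 nM as the nearest pyridine with a number. A step that the limit leaves unreadable from compound 3 to compound 4 is expected, meaning no change beyond the scatter. Compound 4 is therefore estimated at 1500 nM, with a range from 400 nM to 6000 nM.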

Compound 4, inhibition constant: 1160 nM
For compound 4 the middle estimate is 1.3-fold (0.11 log units) above the measured one, and the stated range covers the measured number.
By their numbers in this assay, from the lowest: compounds 2 and 4 (each within the scatter of the next); then compound 1.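

Replacing pyridin-4-yl with 5-cyanopyridin-3-yl in this assay gives a 1.4-fold higher number from compound 2 to compound 4 (0.15 log units; within the scatter), so at this position on the shared core, a pyridine arm carrying a nitrile gives a value that cannot be told apart from that of the plain pyridine. Set against the oxolan-2-yl arm, the same change gives a 2.5-fold lower number from compound 1 to compound 4 (0.41 log units; beyond the scatter), so the modest gain seen with pyridin-4-yl also appears with a second pyridine arm. Compound 3 holds a limit and not a number, so the steps that touch it cannot be read: the limit of > 1000 nM in this assay, at which 1 of the 4 values shown sits.

The compounds shown do not separate the nitrile from the change in how the pyridine ring is attached, and a plain pyridin-3-yl arm would be needed to do so. Going by these compounds, whether an amine or a carboxylic acid in place of the nitrile would shift the number beyond the scatter also stays open.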